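The source may hold more compounds than are shown below. What is called first, only, known or untested is meant among the compounds shown, and "the series" means these compounds.

Compound 1 `c1ccc(-[n+]2c[nH]c3ncncc32)cc1` is the parent of the first pair; in an assay on isolated protein for inhibition of Rho-associated protein kinase 1 (Homo sapiens), tested at 30 uM (on this read-out higher numbers stand for more inhibition at the one concentration tested (going by the name of the read-out) and lower numbers for less inhibition), compound 1 gives 0%. Compound 2 `Fc1ccc(-[n+]2c[nH]c3ncncc32)cc1` differs from it by fluoro in place of hydrogen on an aromatic carbon, and in this assay compound 2 gives 2%, so that a number 2 percentage points higher from compound 1 to compound 2 (within the scatter). Compound 3 `Cn1c(-c2ccc([S+](C)[O-])cc2)nc2c(Sc3ccccc3)ncnc21` rests on another core; how the core of compound 3 differs from the core of compound 1 is not broken down here. In this assay compound 3 gives 1%, a number within the scatter of both compound 1 and compound 2. Compound 4 `Cn1c(-c2ccc([S+](C)[O-])cc2)nc2c(Sc3ccc(F)cc3)ncnc21` has not yet been measured and differs from compound 3 by fluoro in place of hydrogen on an aromatic carbon. It is the same kind of change as between compound 1 and compound 2, but the place is not the same word for word: in compound 2 the fluoro enters para to a group of 9 heavy atoms, in compound 4 para to a large group. Because a number 2 percentage points higher from compound 1 to compound 2 (within the scatter) and compound 3 gives 1%, the expected step is a number 1 percentage points higher from compound 3 to compound 4 (within the scatter). Compound 4 is thus estimated at 2% in this assay, with -6% to 10% as the expected range.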

Compound 4, a percentage reported as inhibition, at one concentration (the size of the read-out at that concentration, not a potency): 0%
Compound 4: the middle estimate sits 2 percentage points above what was measured; low and high end bracket the measured number.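

In this assay, fluoro in place of hydrogen on an aromatic carbon gives a number 1 percentage points lower from compound 3 to compound 4 (within the scatter), and set beside the first pair the result reads: the same change on two cores in this assay, a number 2 percentage points higher (within the scatter) from compound 1 to compound 2 and a number 1 percentage points lower (within the scatter) from compound 3 to compound 4, 3 percentage points apart, within the scatter of two such steps. The two steps therefore do not differ, and on these two cores the change carries over without a difference that can be told from the scatter. This does not show that the change is without consequence on other cores, since compound 1 at 0% and compound 3 at 1% both start from almost no inhibition, so the agreement says nothing about a core on which inhibition can be clearly read.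

Still open, on these data alone, is whether anything other than fluoro at this place, such as an amine or a carboxylic acid, would move the number beyond the scatter on either core. Equally open, as far as these compounds go, is whether a longer chain in place of the phenylsulfanyl group of compound 3 would do so.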